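A few compounds are considered here, and "the series" means these few. Any claim that something is new, unique, unknown or untested is made for them only; others in the source may bear on it.

Measured compounds: compound 1 `C[C@H](Nc1nc(N)nc(N)c1C#N)c1cc2ccc(F)cn2c(=O)c1-c1ccccc1`, 42% in an ADME assay on microsomes from liver (Mus musculus), read by LC-MS, using NADPH, with a stated time of 30 min, tested at 1 uM; on this read-out lower numbers stand for a less stable compound and higher numbers for a more stable compound; compound 2 `C[C@H](Nc1ccnc(N)n1)c1cc2ccc(F)cn2c(=O)c1-c1ccccc1`, "not determined" (no result reported), meaning no number was reported; compound 3 `Cc1nc(N)nc(N[C@@H](C)c2cc3ccc(F)cn3c(=O)c2-c2ccccc2)c1C#N`, 8%.

Compound 1 stands highest of the two numbers in this assay. Its nearest neighbour is compound 3, reached by methyl in place of amino on an aromatic carbon, a large step of a number 34 percentage points lower from compound 1 to compound 3 (beyond the scatter). Compound 4 `C[C@H](Nc1nc(N)nc(N)c1C#N)c1c(-c2ccccc2)c(=O)n2cc(F)ccc2c1-c1ccc(F)cc1` differs from compound 1 by 4-fluorophenyl in place of hydrogen on an aromatic carbon. Among the compounds with values here, no measured step bears on this change; the one known step concerns another position, so it gives no direct guide. A moderate downward step is nonetheless expected, as a number 14 percentage points lower from compound 1 to compound 4 (beyond the scatter). Compound 4 is estimated at 28%, within 8% to 50%.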

Compound 4, percent of the compound remaining in the Mus musculus assay: 83%
Estimate against measurement, compound 4: 55 percentage points below, and the stated range ends below it.
By their numbers in the Mus musculus assay, from the lowest: compound 3; then compound 1; then compound 4.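

Until now only the substituent on the other ring had been varied, and this aromatic carbon of the shared core had carried nothing but hydrogen. In the Mus musculus assay, 4-fluorophenyl at this position gives a number 41 percentage points higher from compound 1 to compound 4 (beyond the scatter), so a large group here does not cost stability and goes with a clear gain. The same change comes with higher lipophilicity in a physicochemical assay for lipophilicity, at pH 7.4; on this read-out lower numbers stand for lower lipophilicity and higher numbers for higher lipophilicity: the measured distribution coefficient of compound 1, 1.26, and of compound 4, 2.38, a number 1.12 log units higher (beyond the scatter) In the physicochemical assay compound 1 gives 1.26 and compound 4 gives 2.38.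

The compounds shown do not separate the effect of the ring from that of its fluorine, since an unsubstituted phenyl or a small methyl at this carbon does not appear among them. On these data alone, whether 4-fluorophenyl would also lift compound 3 stays open.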